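The source may hold more compounds than are shown below. What is called first, only, known or untested is meant among the compounds shown, and "the series" means these compounds.

In an ADME assay on MRC5 cells (Homo sapiens), read by MTT assay, with a stated time of 72 h (on this read-out lower numbers stand for stronger inhibition and higher numbers for weaker inhibition), the three measured compounds stand as follows.
Compound 1, `COc1ncnc2c1c(-c1ccsc1)cn2[C@@H]1O[C@H](CO)[C@@H](O)[C@H]1O`, gives 75300 nM.
Compound 3, `COc1ncnc2c1c(I)cn2[C@@H]1O[C@H](CO)[C@@H](O)[C@H]1O`, gives 63000 nM.
Compound 2, `COc1nc(N)nc2c1c(-c1ccsc1)cn2[C@@H]1O[C@H](CO)[C@@H](O)[C@H]1O`, reaches only > 100000 nM, which is a limit of this assay and not a number.

Among the two numbers, compound 1 holds the higher one, with compound 3 its nearest neighbour at a 1.2-fold lower number from compound 1 to compound 3 (0.08 log units; within the scatter). For compound 2 there is the limit of > 100000 nM in this assay, at which 1 of the 3 values shown sits, so the step of an at least 1.3-fold higher number from compound 1 to compound 2 (0.12 log units; that floor lies within the scatter) is a floor only. Compound 4, `CSc1ncnc2c1c(-c1ccsc1)cn2[C@@H]1O[C@H](CO)[C@@H](O)[C@H]1O`, differs from compound 1 by methylsulfanyl in place of methoxy on an aromatic carbon. Neither measured step touches the methoxy, so neither bears directly on this change, and both stayed within the scatter. Compound 4 is therefore expected to show a 1.1-fold lower number from compound 1 to compound 4 (0.03 log units; within the scatter), nothing beyond the scatter. Compound 4 is estimated at 70000 nM, within 30000 nM to 150000 nM.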

Compound 4, half-maximal inhibitory concentration: > 100000 nM
Compound 4 gave a limit, no number; the forecaster's own chance of this, stated with the estimate: 30%; middle value at least 1.4-fold (0.15 log units) from the limit.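

Methylsulfanyl in place of methoxy, on the carbon next to the ring nitrogen, is the first change here at this position, and it gives an at least 1.3-fold higher number from compound 1 to compound 4 (0.12 log units; that floor lies within the scatter). That figure is only a floor, so the true size of the step could be small or large. Compound 4 gives a limit and not a number, the same limit as compound 2: the limit of > 100000 nM in this assay, at which 2 of the 4 values shown sit.

On these data alone, how an amine, an ethoxy group or a longer chain on this carbon would read stays open. So does how far compound 4 lies past its limit.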